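Thiazole to nitrile: cytotoxicity outlook for compound 4

This account rests on a few compounds, and the source may have more. Where it says the series, first, only, none or still open, it means among the compounds named here.

Compound 1 `CNC(=O)c1ccc(NCc2cncn2Cc2ccc(-c3ccccc3)cc2N)cc1-c1ccccc1` gives in a toxicity assay on NIH3T3 cells (Mus musculus) for cytotoxicity, read by resazurin assay (a lower number here means that less compound is needed, a higher number that more compound is needed for the effect), the value > 1000 nM, a limit of the assay and not a number.
Compound 2 `Nc1cc(-c2ccccc2)ccc1Cn1cncc1CNc1ccc(-c2cncs2)c(-c2ccccc2)c1` gives in this assay the value > 1000 nM, again a limit.
Compound 3 `COC(=O)c1ccc(NCc2cncn2Cc2cccc(C#N)c2)cc1-c1ccccc1` gives in this assay the value > 10000 nM, also a limit.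

Compound 2 thus stands at the limit of > 1000 nM in this assay, at which 2 of the 3 values shown sit. No exact number is known for any of the three; only limits are reported, and compound 3 sits at the limit of > 10000 nM in this assay, at which 1 of the 3 values shown sits.

Compound 4 `N#Cc1ccc(NCc2cncn2Cc2ccc(-c3ccccc3)cc2N)cc1-c1ccccc1` is not yet measured. It differs from compound 2 in one place: cyano in place of 1,3-thiazol-5-yl on an aromatic carbon.

Going by the values given here, only one measured step touches the same position, a step that the two limits leave unreadable from compound 1 to compound 2, and its size cannot be read, since both ends are limits. Among the compounds with values here, there is therefore no measured step that tells how large a change to expect from the cyano in place of 1,3-thiazol-5-yl.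

Given that every value so far is a limit, compound 4 is expected to give in this assay about 3000 nM, most likely again reported as a limit, with a range from 1000 nM to 20000 nM. The expected step is a step that the limit leaves unreadable from compound 2 to compound 4, no change beyond the scatter.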

Compound 4, half-maximal effective concentration: > 1000 nM
Compound 4 ended at the assay's limit (the forecaster's own chance of this, stated with the estimate: 85%); the middle value is on the limit's open side.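

The steps from compound 2 to compound 4 and from compound 1 to compound 4 cannot be read in this assay, as all three compounds are reported only as a limit and not as a number: the limit of > 1000 nM in this assay, at which 3 of the 4 values shown sit.

The compounds shown leave open the actual concentration each one needs for the effect, and so whether cyano, 1,3-thiazol-5-yl or methylcarbamoyl on this aromatic carbon makes any difference.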